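The source may hold more compounds than are shown below. What is called first, only, known or untested is meant among the compounds shown, and "the series" means these compounds.

Compound 1 `COc1ccccc1C(=O)Nc1[nH]nc(-c2ccccn2)c1C1CC1` carries a 2-methoxyphenyl on the carbonyl carbon of its amide. In an ADME assay on cells (Peritoneal macrophage cell, Mus musculus) for cytotoxicity, read by fluorescence and resazurin assay, with a stated time of 3 days (a lower number here means that less compound is tolerated, a higher number that more compound is tolerated), compound 1 reaches only a limit of > 51000 nM, so no number for it is known. Compound 2 `O=C(Nc1cc(-c2ccccn2)n[nH]1)N1CCC(Oc2ccccc2)CC1` is a urea analogue in the same series. In this assay compound 2 likewise gives only a limit, > 40000 nM. Compound 3 `N#Cc1ccc(OC2CCN(C(=O)Nc3cc(-c4ccccn4)n[nH]3)CC2)cc1` carries a cyano in place of hydrogen on an aromatic carbon relative to compound 2. In this assay compound 3 gives a limit of > 64000 nM. The step that the two limits leave unreadable from compound 2 to compound 3 is therefore unreadable, as the limit of > 40000 nM in this assay, at which 1 of the 3 values shown sits, and the limit of > 64000 nM in this assay, at which 1 of the 3 values shown sits, show. Compound 4 `COc1ccc(C(=O)Nc2[nH]nc(-c3ccccn3)c2C2CC2)cc1` is the unmeasured analogue, with 4-methoxyphenyl in place of 2-methoxyphenyl on a carbonyl carbon. For the measured compounds named here, no measured step touches this change, and every value so far sits at a limit (the limit of > 40000 nM in this assay, at which 1 of the 3 values shown sits, (the limit of > 51000 nM in this assay, at which 1 of the 3 values shown sits), (the limit of > 64000 nM in this assay, at which 1 of the 3 values shown sits)), so a fourth limit is the most likely outcome. The step that the limit leaves unreadable from compound 1 to compound 4 is expected to lie within the scatter. Compound 4 is estimated at 60000 nM, with a range of 25000 nM to 150000 nM.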

Compound 4, half-maximal cytotoxic concentration: > 64000 nM
Compound 4: only a limit was reported; the forecaster's own chance of this, stated with the estimate: 85%; middle value at least 1.0-fold (0.02 log units) away from the limit.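

Compound 1 and compound 4 both give only limits in this assay, and the step between them cannot be read. The compounds shown leave open where the half-maximal cytotoxic concentration of any of them lies, and whether 4-methoxyphenyl in place of 2-methoxyphenyl on a carbonyl carbon changes it.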